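The source may report more compounds than this note shows. Statements on the series, on what has been measured and on what is new or still open speak of the compounds shown alone.

Measured compounds:
Compound 1, `COc1cccc(CNc2ncnc3c2ncn3[C@@H]2O[C@H](CO)[C@@H](O)[C@H]2O)c1OC`: > 166000 nM
Compound 2, `COc1cc(CNc2ncnc3c2ncn3[C@@H]2O[C@H](CO)[C@@H](O)[C@H]2O)cc(OC)c1O`: > 166000 nM
Compound 3, `COc1cc(O)cc(OC)c1CNc1ncnc2c1ncn2[C@@H]1O[C@H](CO)[C@@H](O)[C@H]1O`: > 166000 nM

Compound 1 carries the structure `COc1cccc(CNc2ncnc3c2ncn3[C@@H]2O[C@H](CO)[C@@H](O)[C@H]2O)c1OC`. In a functional assay on MCF cells (Homo sapiens) for antiproliferative activity, with a stated time of 72 h (on this read-out lower numbers stand for stronger inhibition and higher numbers for weaker inhibition), compound 1 gives only a limit, > 166000 nM, and no number. Compound 2, with the structure `COc1cc(CNc2ncnc3c2ncn3[C@@H]2O[C@H](CO)[C@@H](O)[C@H]2O)cc(OC)c1O`, likewise gives only a limit, > 166000 nM. Compound 3, `COc1cc(O)cc(OC)c1CNc1ncnc2c1ncn2[C@@H]1O[C@H](CO)[C@@H](O)[C@H]1O`, also gives only a limit, > 166000 nM. So compound 1 stands nowhere that can be ranked: every value shown is a limit, and the limit of > 166000 nM in this assay, at which 3 of the 3 values shown sit, marks where all three sit. Among the measured compounds shown here, no step between two measured compounds with a single difference is known, so the size of any step in this assay rests on nothing measured.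

Compound 4 has the structure `OC[C@H]1O[C@@H](n2cnc3c(NCc4cccc(C(F)(F)F)c4)ncnc32)[C@H](O)[C@@H]1O`. It differs from compound 1 by 3-(trifluoromethyl)phenyl in place of 2,3-dimethoxyphenyl on a saturated chain carbon bound to a nitrogen on an aromatic ring. The three measured compounds all carry oxygen-bearing phenyl groups and all reach only the limit; compound 4 carries none. An estimate for compound 4 must therefore lean on the limits alone, and the step of an at least 1.3-fold lower number from compound 1 to compound 4 (0.14 log units; that floor lies within the scatter) is expected to be small or none beyond the scatter. Compound 4 is expected to give about 120000 nM, between 30000 nM and 400000 nM, most likely again a limit.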

Compound 4, half-maximal inhibitory concentration: > 166000 nM
Compound 4: only a limit was reported (the forecaster's own chance of this, stated with the estimate: 70%); middle value at least 1.3-fold (0.14 log units) from the limit.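

In this assay compound 4 gives > 166000 nM, which is a limit. Among the compounds shown here, compound 1 also gives only a limit, so no step between compound 1 and compound 4 can be read. The compounds shown leave open whether any phenyl group here yields a measurable number in this assay, since all values sit at one limit: the limit of > 166000 nM in this assay, at which 4 of the 4 values shown sit.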